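Trimming the Sulfonyl Aryl Group from Biphenyl to Phenyl

The source may report more compounds than this note shows. Statements on the series, on what has been measured and on what is new or still open speak of the compounds shown alone.

Three hydroxamic acids sharing one core have been measured in a functional assay on MCF7 cells (Homo sapiens) for antiproliferative activity; on this read-out lower numbers stand for stronger inhibition of growth and higher numbers for weaker inhibition of growth. Compound 1 `O=C(/C=C/c1cnc(N2CCN(S(=O)(=O)c3ccc4ccccc4c3)CC2)s1)NO` carries a naphthyl group on the sulfonyl and gives 700 nM. Compound 2 `O=C(/C=C/c1cnc(N2CCN(S(=O)(=O)c3ccc(OC(F)(F)F)cc3)CC2)s1)NO` carries a trifluoromethoxy-substituted phenyl and gives 6000 nM. Compound 3 `O=C(/C=C/c1cnc(N2CCN(S(=O)(=O)c3ccc(-c4ccccc4)cc3)CC2)s1)NO` carries a biphenyl and gives 1500 nM; on these numbers compound 3 stands second behind compound 1 and ahead of compound 2. Going by the values given here, the only single-point step among the measured compounds is a 4.0-fold lower number from compound 2 to compound 3 (0.60 log units; beyond the scatter), which shows that the larger aryl group gave the lower number.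

Compound 4 `O=C(/C=C/c1cnc(N2CCN(S(=O)(=O)c3ccccc3)CC2)s1)NO` is the unsubstituted analogue: hydrogen in place of phenyl on an aromatic carbon. Among the compounds with values here, no measured pair removes a substituent outright, so the step from compound 2 to compound 3 is the nearest guide, and it points the other way, since the bulkier aryl groups in compound 1 and compound 3 sit at the lower numbers. Removing the phenyl is therefore expected to raise the number in this assay by a modest amount, in the same range as the step from compound 2 to compound 3. The expected step is a 2.3-fold higher number from compound 3 to compound 4 (0.37 log units; beyond the scatter). For compound 4 the estimate is 3500 nM, with a likely range from 1200 nM to 10000 nM.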

Compound 4, concentration for 50% growth inhibition: 3000 nM
The estimate for compound 4 lay 1.2-fold (0.07 log units) above the measured number; the range from low to high includes it.
By their numbers in this assay, from the lowest: compound 1; then compounds 3, 4 and 2 (each within the scatter of the next, the first and the last beyond it).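

In this assay, hydrogen in place of phenyl on the aromatic carbon gives a 2.0-fold higher number from compound 3 to compound 4 (0.30 log units; within the scatter) and so shows that the outer phenyl of the biphenyl is not needed to hold the number within the scatter of the unsubstituted analogue. Hydrogen in place of trifluoromethoxy gives a 2.0-fold lower number from compound 2 to compound 4 (0.30 log units; within the scatter) and likewise cannot be told apart, so the bare phenyl sits within the scatter of two substituted rings that differ from each other, with a 4.0-fold lower number from compound 2 to compound 3 (0.60 log units; beyond the scatter) as the step that separates them. Going by these compounds alone, only the fused aryl group stands clear of the bare phenyl, since phenyl in place of naphthalen-2-yl on the sulfonyl sulfur gives a 4.3-fold higher number from compound 1 to compound 4 (0.63 log units; beyond the scatter) as the one new step beyond the scatter. Nothing given here offers any measured account of these differences.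

With only hydrogen, phenyl and trifluoromethoxy at this aromatic carbon, the compounds shown leave open what a small group such as fluoro or methyl, or a charged one such as an amine or a carboxylic acid, would do there. They also leave open whether a quinoline or another fused ring would match the naphthalen-2-yl group on the sulfonyl sulfur.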